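The source may hold more compounds than are shown below. What is called first, only, known or untested is meant among the compounds shown, and "the series" means these compounds.

Within the series, compound 2 `Cn1ncc(Cl)c1-c1cc(C(=O)N[C@@H]2CN[C@H](CC(=O)O)C[C@H]2c2ccc(Cl)c(Cl)c2)oc1Cl` gives the lowest of the two numbers recorded so far in an assay for inhibition of RAC-alpha serine/threonine-protein kinase (Homo sapiens), read by HTRF, with a stated time of 1 h (on this read-out lower numbers stand for stronger inhibition and higher numbers for weaker inhibition), at 1.94 nM; compound 1 `Cn1ncc(Cl)c1-c1cc(C(=O)N[C@@H]2CN[C@H](CC(N)=O)C[C@H]2c2ccc(Cl)c(Cl)c2)oc1Cl` gives 3.24 nM, and the step of a 1.7-fold lower number from compound 1 to compound 2 (0.22 log units; within the scatter) stays within the scatter. Compound 3 `C=CC[C@@H]1C[C@@H](c2ccc(Cl)c(Cl)c2)[C@H](NC(=O)c2cc(-c3c(Cl)cnn3C)c(Cl)o2)CN1` carries a further change: vinyl in place of carboxy on a saturated chain carbon bound to a saturated ring carbon. Among the compounds with values here, no measured step involves removal of the carboxymethyl group altogether, so the one known step offers no direct guide. As the group lost bears one hydrogen-bond donor and one acceptor, a modest weakening is expected, a 2.3-fold higher number from compound 2 to compound 3 (0.37 log units; beyond the scatter). Compound 3 is therefore estimated at 4.5 nM, with a range of 1.5 nM to 15 nM.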

Compound 3, half-maximal inhibitory concentration: 12.4 nM
Compound 3: the middle estimate sits 2.8-fold (0.44 log units) below what was measured, within the range that was stated.
By their numbers in this assay, from the lowest: compounds 2 and 1 (each within the scatter of the next); then compound 3.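

In this assay a change on this saturated chain carbon bound to a saturated ring carbon now goes beyond the scatter: vinyl in place of carboxy gives a 6.4-fold higher number from compound 2 to compound 3 (0.81 log units; beyond the scatter) here, and vinyl in place of carbamoyl gives a 3.8-fold higher number from compound 1 to compound 3 (0.58 log units; beyond the scatter) at the same place. Carboxy and carbamoyl differ only within the scatter, whereas compound 3, whose vinyl carries no hydrogen-bond donor or acceptor, stands apart from both.

As far as these compounds go, whether an amine, a hydroxyl or a longer carboxylic acid chain here would sit with compound 3 remains open. Nothing available explains the size of these steps.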